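Heptyl for tert-butoxy in a level pair

This account rests on a few compounds, and the source may have more. Where it says the series, first, only, none or still open, it means among the compounds named here.

In an ADME assay on a cell-free system (plasma, Homo sapiens) for metabolic stability, read by LC-MS, with a stated time of 1 h, tested at 10 uM (on this read-out lower numbers stand for a less stable compound and higher numbers for a more stable compound), compound 1 `CC(=O)NCCCC[C@H](NC(=O)[C@@H]1Cc2ccccc2CN1)C(=O)N[C@@H](CCC(=O)C=[N+]=[N-])C(=O)OC(C)C` gives 95% and compound 2 `CC(=O)NCCCC[C@H](NC(=O)OC(C)(C)C)C(=O)N[C@@H](CCC(=O)C=[N+]=[N-])C(=O)OC(C)C` gives 95% as well, so the two stand level. Compound 3 `CCCCCCCC(=O)N[C@@H](CCCCNC(C)=O)C(=O)N[C@@H](CCC(=O)C=[N+]=[N-])C(=O)OC(C)C` follows with heptyl in place of tert-butoxy on a carbonyl carbon. For the measured compounds named here, the only measured step at that place is no change at the digits printed from compound 1 to compound 2 (within the scatter) for tert-butoxy in place of 1,2,3,4-tetrahydroisoquinolin-3-yl. A step of similar size is expected, none beyond the scatter in either direction, estimated as a number 2 percentage points lower from compound 2 to compound 3 (within the scatter) in this assay for this exchange. Compound 3 is expected at 93% with an estimated range of 78% to 100% for its reading.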

Compound 3, percent of the compound remaining: 95%
Beside the measured number, compound 3's estimate is 2 percentage points below it, and the stated range covers the measured number.
By their numbers in this assay, from the lowest: compounds 1, 2 and 3 (each within the scatter of the next).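

Putting heptyl on the carbonyl carbon in place of tert-butoxy gives no change at the digits printed from compound 2 to compound 3 (within the scatter) in this assay, and putting it there in place of 1,2,3,4-tetrahydroisoquinolin-3-yl gives no change at the digits printed from compound 1 to compound 3 (within the scatter). This position has now carried a group with a ring and two groups with no ring, one of them free of oxygen, and the reading stays level across all three. No supporting information offers an explanation for this flat reading. From the compounds shown here alone, whether an amine or a carboxylic acid on this carbonyl carbon would stay level with these three remains open.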